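Pyrimidine for pyridine at the ethynyl-bearing arm

The compounds below may be only part of what the source reports. "The series", "measured", "known", "first", "only" and "open" are said of these compounds alone.

For the measured compounds named here, compound 2 `C#Cc1ccnc(C#Cc2ccc3ncn(-c4ccnc(N)n4)c3c2)c1` holds the lowest of the two numbers so far in an assay on Sf9 cells for inhibition of mitogen-activated protein kinase kinase kinase 14 variant S549D (Homo sapiens), with a stated time of 30 min, in the presence of a further agent that is not named here (a lower number here means a stronger inhibitor, a higher number a weaker inhibitor), where compound 2 gives 316 nM. Going by the values given here, its nearest neighbour is compound 1 `C#Cc1cccc(C#Cc2ccc3ncn(-c4ccnc(N)n4)c3c2)n1`, which in this assay gives 3160 nM; the only measured step, a 10-fold lower number from compound 1 to compound 2 (1.00 log units; beyond the scatter), separates them, and it replaced one six-membered aromatic ring bearing a single hetero atom with another of the same kind on a triple-bonded carbon.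

Compound 3 `C#Cc1cnc(C#Cc2ccc3ncn(-c4ccnc(N)n4)c3c2)nc1` is not yet measured. It differs from compound 2 as follows: a group of 8 heavy atoms (6 carbon, 2 nitrogen; one six-membered aromatic ring with 2 hetero atoms) in place of a group of 8 heavy atoms (7 carbon, 1 nitrogen; one six-membered aromatic ring with 1 hetero atom), on a triple-bonded carbon. The arm that carries the terminal triple bond therefore changes from a ring with one hetero atom to a ring with two, while the rest of the molecule stays the same.

The measured step from compound 1 to compound 2 bears on this only loosely, since that step exchanged one ring with one hetero atom for another, not a ring with two. Compound 3 is therefore expected to stay close to compound 2, with a step of a 1.3-fold higher number from compound 2 to compound 3 (0.10 log units; within the scatter) in this assay that may well lie within the scatter. Compound 3 is estimated to give 400 nM in this assay, with a likely range from 130 nM to 1300 nM.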

Compound 3, half-maximal inhibitory concentration: 25100 nM
The estimate for compound 3 lay 63-fold (1.80 log units) below the measured number; the measured number lies above the stated range.
By their numbers in this assay, from the lowest: compound 2; then compound 1; then compound 3.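

In this assay, the arm on the triple-bonded carbon proves far less tolerant than the single earlier step could show: replacing the 4-ethynylpyridin-2-yl group with the ring bearing two hetero atoms gives a 79-fold higher number from compound 2 to compound 3 (1.90 log units; beyond the scatter), the largest step among these compounds. The same arm also falls behind the other ring with one hetero atom, with a 7.9-fold higher number from compound 1 to compound 3 (0.90 log units; beyond the scatter), so compound 3 is the weakest of the three and both arms with a single ring hetero atom rank ahead of it. Nothing available here bears on the reason for this loss.

With only these three arms, the effect of the number of ring nitrogens cannot be separated from the effect of where they sit, since the two arms with one hetero atom already differ by a 10-fold lower number from compound 1 to compound 2 (1.00 log units; beyond the scatter). Also open, going by these compounds, is how a phenyl ring with no ring nitrogen would rank against them, and whether an amine or a methyl group in place of the ethynyl group would preserve the order seen here.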